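The compounds below may be only part of what the source reports. "The series", "measured", "known", "first", "only" and "open" are said of these compounds alone.

In a functional assay on MCF7 cells (Homo sapiens) for antiproliferative activity, read by MTT assay, with a stated time of 72 h (a higher number here means a weaker inhibitor, a lower number a stronger inhibitor), compound 3 (`CCC(=O)NNC(=O)c1csc2ncc(-c3ccc(OC)cc3)n12`) gives 53200 nM and compound 1 (`CCCC(=O)NNC(=O)c1csc2ncc(-c3ccc(C)cc3)n12`) gives 41700 nM, two numbers within the scatter of each other, while compound 2 (`COc1ccc(-c2cnc3scc(C(=O)NNC(C)=O)n23)cc1`) gives the clearly lower, stronger 8360 nM in the same test.

Compound 4 (`CCCC(=O)NNC(=O)c1csc2ncc(-c3ccc(OC)cc3)n12`) differs from compound 3 by one change (methyl in place of hydrogen on a saturated chain carbon, two bonds along the chain from a carbonyl carbon): methyl in place of hydrogen on a saturated chain carbon, two bonds along the chain from a carbonyl carbon. The closest measured precedent is methyl in place of hydrogen on a saturated chain carbon bound to a carbonyl carbon (a 6.4-fold higher number from compound 2 to compound 3 (0.80 log units; beyond the scatter)), a modest step beyond the scatter toward weaker activity. That single step cannot show whether the trend continues. Sharing the propylcarbonyl group of compound 4 but differing elsewhere in the molecule, compound 1 gives 41700 nM and so offers no sign of a further climb.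

In this assay no step beyond the scatter is therefore expected, and the estimated step is small (a 1.2-fold lower number from compound 3 to compound 4 (0.07 log units; within the scatter)) in size. Compound 4 is expected at 45000 nM with an estimated range between 20000 nM and 100000 nM as the likely span.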

Compound 4, half-maximal inhibitory concentration: 32800 nM
Beside the measured number, compound 4's estimate is 1.4-fold (0.14 log units) above it; the range from low to high includes it.
By their numbers in this assay, from the lowest: compound 2; then compounds 4, 1 and 3 (each within the scatter of the next).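

In this assay, methyl at this chain carbon, which turns propanoyl into propylcarbonyl, gives a 1.6-fold lower number from compound 3 to compound 4 (0.21 log units; within the scatter), so the climb seen one carbon closer to the carbonyl does not carry on here. Compound 4 still stands apart from the shorter chain of compound 2, with a 3.9-fold higher number from compound 2 to compound 4 (0.59 log units; beyond the scatter), so the longer chain keeps a gap beyond the scatter. On the aromatic carbon, methoxy in place of methyl gives a 1.3-fold lower number from compound 1 to compound 4 (0.10 log units; within the scatter), again within the scatter, and nothing available here explains any of these steps.

From the compounds shown here alone, whether a still longer chain, or a chain ending in an amine or a carboxylic acid, would stay level with compound 4 remains open. So does whether methoxy and methyl would also match on the shorter chain of compound 2.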